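A few compounds are considered here, and "the series" means these few. Any claim that something is new, unique, unknown or untested is made for them only; others in the source may bear on it.

Three compounds of this set have measured numbers. Compound 1 `Clc1ccc(-c2cc(-c3ccoc3)cc(-c3ccco3)n2)s1` gives 1280 nM in a functional assay on HCT-15 cells (Homo sapiens) for cytotoxicity, read by ELISA, with a stated time of 4 days; a higher number here means a weaker inhibitor, a lower number a stronger inhibitor. Compound 2 `Clc1cccc(-c2cc(-c3ccoc3)cc(-c3ccc(Cl)s3)n2)c1` differs from compound 1 by 3-chlorophenyl in place of furan-2-yl on an aromatic carbon; in this assay compound 2 gives 950 nM, so the step of a 1.3-fold lower number from compound 1 to compound 2 (0.13 log units; within the scatter) is small. Compound 3 `Cc1ccsc1-c1cc(-c2ccc(Cl)o2)cc(-c2ccco2)n1` gives 26300 nM in this assay , the highest of the three numbers; how its core differs from the core of compound 1 is not broken down here. Compound 4 `Cc1ccsc1-c1cc(-c2ccc(Cl)o2)cc(-c2cccc(Cl)c2)n1` is not yet measured and differs from compound 3 by 3-chlorophenyl in place of furan-2-yl on an aromatic carbon. The surroundings are not identical: in compound 1 the changed carbon is meta to a 5-chlorothiophen-2-yl group and meta to a furan-3-yl group, while in compound 3 it is meta to a 3-methylthiophen-2-yl group and meta to a 5-chlorofuran-2-yl group, so this is the same kind of change, not the same one. The step of a 1.2-fold lower number from compound 3 to compound 4 (0.08 log units; within the scatter) is expected to stay small, because the earlier step of a 1.3-fold lower number from compound 1 to compound 2 (0.13 log units; within the scatter) lay within the scatter. Compound 4 is therefore estimated at 22000 nM, somewhere between 8000 nM and 60000 nM.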

Compound 4, half-maximal inhibitory concentration: 26400 nM
Beside the measured number, compound 4's estimate is 1.2-fold (0.08 log units) below it; the measured number falls inside the stated range.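

In this assay, putting 3-chlorophenyl in place of furan-2-yl gives a 1.0-fold higher number from compound 3 to compound 4 (0.00 log units; within the scatter), so on this core the swap makes no readable difference to the number. The same swap on the earlier core behaved no differently, and the two results agree: the same change on two cores in this assay, a 1.3-fold lower number (0.13 log units; within the scatter) from compound 1 to compound 2 and a 1.0-fold higher number (0.00 log units; within the scatter) from compound 3 to compound 4, 1.4-fold (0.13 log units) apart, within the scatter of two such steps. This shows that, for these two cores, the swap carried over from one to the other as a change too small to read, but two pairs are a small sample, so it cannot show that the same would hold on any other core, or in any test other than this one.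

At this aromatic carbon, next to the ring nitrogen, the compounds shown carry only furan-2-yl or 3-chlorophenyl, so the result describes just that one exchange of aromatic rings. As far as these compounds go, whether an amine, a carboxylic acid or a longer chain on the same carbon would shift the number remains open.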